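The source may report more compounds than this note shows. Statements on the series, on what has been measured and on what is new or still open speak of the compounds shown alone.

In an assay on isolated protein for binding affinity to sphingosine 1-phosphate receptor 2 (Homo sapiens), read by surface plasmon resonance (a higher number here means weaker binding, a lower number tighter binding), compound 3 `COc1cc(NC(=O)NNc2cc(-c3ccc(F)cc3)c3cnn(C)c3n2)cc(Cl)n1` gives 1650 nM. Of the three measured compounds it shows the lowest number, though the separation from compound 2 `CCN(CC)c1cc(NC(=O)NNc2cc(-c3ccc(F)cc3)c3cnn(C)c3n2)cc(Cl)n1`, which gives 3150 nM, lies within the scatter a 1.9-fold lower number from compound 2 to compound 3 (0.28 log units; within the scatter). Compound 1 `COc1cc(NC(=O)NNc2cc(-c3ccccc3)c3cnn(C)c3n2)cc(Cl)n1` gives 3640 nM, and the step from there to compound 3 is beyond the scatter, though modest a 2.2-fold lower number from compound 1 to compound 3 (0.34 log units; beyond the scatter).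

Compound 4 `Cn1ncc2c(-c3ccc(F)cc3)cc(NNC(=O)Nc3cc(F)cc(F)c3)nc21` carries 3,5-difluorophenyl in place of 2-chloro-6-methoxypyridin-4-yl on an amide-type nitrogen. Neither measured step touches this part of the molecule in the same way: the step from compound 2 to compound 3 swaps one substituent on the ring that now leaves, and the step from compound 1 to compound 3 alters the other aryl group. Both were small, which suggests this assay responds only mildly to changes at either end. For the measured compounds named here, the present change is larger than either and has no direct precedent here, so the direction is open. Compound 4 is therefore expected to land near compound 3, with a step of a 1.2-fold higher number from compound 3 to compound 4 (0.08 log units; within the scatter) and an estimated 2000 nM, between 800 nM and 5000 nM.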

Compound 4, dissociation constant: 3980 nM
Estimate against measurement, compound 4: 2.0-fold (0.30 log units) below; the measured number falls inside the stated range.
By their numbers in this assay, from the lowest: compounds 3, 2, 1 and 4 (each within the scatter of the next, the first and the last beyond it).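

In this assay, 3,5-difluorophenyl in place of 2-chloro-6-methoxypyridin-4-yl on the amide-type nitrogen gives a 2.4-fold higher number from compound 3 to compound 4 (0.38 log units; beyond the scatter), and this is the first change shown that replaces the whole group at this position rather than one substituent on it. The step lies beyond the scatter but is modest, so binding survives when the ring nitrogen, the chloro and the methoxy all leave together, at a small cost in the number. Nothing available here explains why the number rises with this change.

The compounds shown leave open which of the three departing features accounts for the step, as all of them change at once in compound 4. They also leave open how this position would respond to an amine, a carboxylic acid or a morpholine on the aromatic ring.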